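Sulfonyl hydrazide series: bromo to carboxyethyl at the para position

This account rests on a few compounds, and the source may have more. Where it says the series, first, only, none or still open, it means among the compounds named here.

Measured so far:
compound 1 `Cc1cccc(NNS(=O)(=O)c2ccc(C#N)cc2)c1` — 59 nM
compound 2 `O=S(=O)(NNc1ccc(Br)cc1)c1ccc(Br)cc1` — 85 nM

In an assay for inhibition of Indoleamine 2,3-dioxygenase 1 (Homo sapiens), read by spectrophotometry, with stated times of 1 h and 4 h (a lower number here means a stronger inhibitor, a higher number a weaker inhibitor), compound 2 gives 85 nM and stands highest of the two numbers; compound 1 gives 59 nM, within the scatter of it. For the measured compounds named here, no step between measured compounds is recorded. Compound 3 `O=C(O)CCc1ccc(S(=O)(=O)NNc2ccc(Br)cc2)cc1` differs from compound 2 by 2-carboxyethyl in place of bromo on an aromatic carbon. Going by the values given here, both measured compounds carry a small group at this place; a 2-carboxyethyl group there has no precedent, so the step is uncertain. A modest step to a higher number, around the edge of the scatter, is expected: a 2.4-fold higher number from compound 2 to compound 3 (0.37 log units; beyond the scatter). For compound 3 the estimate is 200 nM, with a range from 50 nM to 1000 nM.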

Compound 3, half-maximal inhibitory concentration: 141 nM
Compound 3: middle estimate off by 1.4-fold (0.15 log units), on the high side; low and high end bracket the measured number.
By their numbers in this assay, from the lowest: compounds 1, 2 and 3 (each within the scatter of the next, the first and the last beyond it).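

In this assay, for the compounds shown here, 2-carboxyethyl in place of bromo gives a 1.7-fold higher number from compound 2 to compound 3 (0.22 log units; within the scatter), the only step here that changes a single place. This position, on an aromatic carbon para to a large group, therefore takes a chain bearing a hydrogen-bond donor and acceptor with no step beyond the scatter. Nothing on hand accounts for this result. From the compounds shown here alone, whether the carboxylic acid end or the chain itself sets the number remains open. A methyl ester, a primary amine or a longer chain at this position would separate the two.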